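Methoxy to hydroxy on a pyrazole series

This account rests on a few compounds, and the source may have more. Where it says the series, first, only, none or still open, it means among the compounds named here.

Within the data shown here, the three compounds measured so far share one core and are tested in a functional assay on RXF 393 cells (Homo sapiens) for cytotoxicity, read by sulforhodamine B assay, with a stated time of 48 h, tested at 0.01 uM; a higher number here means a weaker effect of the compound at the concentration tested, a lower number a stronger effect. Compound 1 `COc1cc(C)cc(-c2c(-c3ccnc(-c4ccc(N(C)C)cc4)c3)cnn2CC#N)c1` gives 84%. Compound 3 `COc1cc(C)cc(-c2nn(CC#N)cc2-c2ccc(-c3cccc(C(C)=O)c3)nc2)c1` gives 89%. Compound 2 `COc1cc(C)cc(-c2nn(CC#N)cc2-c2ccnc(-c3ccc(N(C)C)cc3)c2)c1` gives 103%, which is the highest of the three numbers: the nearest number, that of compound 3, lies below it by an amount beyond the scatter, and the furthest, that of compound 1, lies below it by a still larger amount beyond the scatter. At this concentration every one of the three compounds leaves most of the cells in place, so all of the effects are weak.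

Compound 4 `Cc1cc(O)cc(-c2nn(CC#N)cc2-c2ccnc(-c3ccc(N(C)C)cc3)c2)c1` has not yet been measured in this assay. It differs from compound 2 in a single spot: hydrogen in place of methyl on an oxygen on an aromatic ring. Read one bond further out, the change is methoxy to hydroxy, so the 3-methoxy-5-methylphenyl of compound 2 becomes 3-hydroxy-5-methylphenyl.

Among the measured compounds shown here, no measured pair in this set records that same change, so nothing here tells how large a shift it brings. With compound 2 at 103% and compound 1 and compound 3 only modestly lower, the step of a number 9 percentage points lower from compound 2 to compound 4 (within the scatter) is expected to be small, at most a slight move toward a stronger effect, and may well stay within the scatter. Compound 4 is therefore estimated at 94%, with a likely range from 78% to 108%.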

Compound 4, a percentage reported as activity, at one concentration (the size of the read-out at that concentration, not a potency): 104%
For compound 4 the middle estimate is 10 percentage points below the measured one; measured number inside the range.
By their numbers in this assay, from the lowest: compounds 1 and 3 (each within the scatter of the next); then compounds 2 and 4 (each within the scatter of the next).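

In this assay, among these compounds, the change from methoxy to hydroxy, which turns 3-methoxy-5-methylphenyl into 3-hydroxy-5-methylphenyl, gives a number 1 percentage points higher from compound 2 to compound 4 (within the scatter) and supplies the only reading of this change in the set. The pair shows that, at this single concentration, the methyl on the oxygen on the aromatic ring can be replaced by hydrogen without the read-out moving beyond the usual scatter, so the two compounds cannot be told apart here, and each leaves the number at a level that means a weak effect. No measurement at hand bears on why the methoxy and hydroxy forms read alike, and none gives a property of either group.

One pair at one concentration cannot show whether the two compounds would also read alike at a concentration where the effect is strong, or whether the same change would behave in the same way on compound 1 or compound 3, which also carry the methoxy group. Also open, as far as these compounds go, is how the read-out would respond to an ethoxy group, a longer chain on that oxygen, or an amine in place of the hydroxy.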